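Ester variation in a dihydropyrimidinone series at the A3 receptor

A few compounds are considered here, and "the series" means these few. Any claim that something is new, unique, unknown or untested is made for them only; others in the source may bear on it.

Measured compounds:
compound 1 `CCCOC(=O)C1=C(C)NC(=O)NC1c1ccco1`, 3%
compound 2 `CC1=C(C(=O)OCc2ccccc2)C(c2ccco2)NC(=O)N1`, 3%
compound 3 `CC1=C(C(=O)OCC(C)C)C(c2ccoc2)NC(=O)N1`, 16%

Working notes. In an assay on membranes from HeLa cells for displacement of a labelled ligand from adenosine receptor A3 (Homo sapiens), read by scintillation counting, with a stated time of 180 min, tested at 1 uM (a higher number here means more inhibition at the concentration tested (going by the name of the read-out), a lower number less inhibition), compound 3 gives the highest of the three numbers; both compound 1 and compound 2 lie lower by a gap beyond the scatter, and the two of them sit within the scatter of each other.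

Compound 4 `CC1=C(C(=O)OCc2ccccc2)C(c2ccoc2)NC(=O)N1` is not yet measured. It differs from compound 3 in one place: phenyl in place of isopropyl on a saturated chain carbon bound to an oxygen next to a carbonyl group.

Within the data shown here, one measured step bears on this change. The same kind of exchange at the same place, on the core of compound 1, gave no change at the digits printed from compound 1 to compound 2 (within the scatter). That step replaced ethyl rather than isopropyl with phenyl, so it is the closest available guide; a second guide of this exact kind does not exist in the data.

On that basis no step beyond the scatter is expected from compound 3 to compound 4, and the expected step is a number 2 percentage points lower from compound 3 to compound 4 (within the scatter). Compound 4 is therefore estimated at 14% in this assay, with a range from 2% to 28%, allowing for the possibility that the small advantage of compound 3 is not kept.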

Compound 4, a percentage reported as inhibition, at one concentration (the size of the read-out at that concentration, not a potency): 1%
Beside the measured number, compound 4's estimate is 13 percentage points above it; the whole stated range lies above it.
By their numbers in this assay, from the lowest: compounds 4, 1 and 2 (each within the scatter of the next); then compound 3.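

In this assay, replacing isopropyl with phenyl on a saturated chain carbon bound to an oxygen next to a carbonyl group gives a number 15 percentage points lower from compound 3 to compound 4 (beyond the scatter) and is therefore a readable change at this position, while the ethyl to phenyl exchange on the core of compound 1 gave no change at the digits printed from compound 1 to compound 2 (within the scatter) and showed no such sensitivity. With the benzyl group held constant, furan-3-yl in place of furan-2-yl on a saturated ring carbon gives a number 2 percentage points lower from compound 2 to compound 4 (within the scatter), so the furan change alone does not separate these two compounds, and the standing of compound 3 rests on its isobutyl group paired with furan-3-yl. Nothing available explains the loss on going from isobutyl to benzyl.

Among these compounds, it remains open whether isobutyl would also stand apart on the furan-2-yl core, as compound 3 is the only example carrying that group, and all four readings are low inhibition at a single concentration rather than potencies. Also open, going by these compounds, is how this position responds to a longer chain, a cyclohexyl group or an amide in place of the ester.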